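Sulfonyl substituent change in the aorta series

A few compounds are considered here, and "the series" means these few. Any claim that something is new, unique, unknown or untested is made for them only; others in the source may bear on it.

Compound 2 `CC1(C)C=C(n2ccccc2=O)c2cc(S(=O)(=O)Nc3ccc([N+](=O)[O-])cc3)ccc2O1` gives 82.2% in a functional assay on the whole organism (aorta) with Rattus norvegicus as the target; on this read-out higher numbers stand for larger maximal responses and lower numbers for smaller maximal responses; compound 1 `CC1(C)C=C(n2ccccc2=O)c2cc(S(=O)(=O)Nc3ccc(C#N)cc3)ccc2O1` gives 84% in this assay, and the step of a number 1.8 percentage points lower from compound 1 to compound 2 (within the scatter) leaves the two within the usual scatter, so compound 2 is not set apart from compound 1 beyond that scatter. Compound 3 `CN(C)S(=O)(=O)c1ccc2c(c1)C(n1ccccc1=O)=CC(C)(C)O2` differs from compound 2 by dimethylamino in place of (4-nitrophenyl)amino on a sulfonyl sulfur. Among the compounds with values here, the only measured step, a number 1.8 percentage points lower from compound 1 to compound 2 (within the scatter), concerns nitro in place of cyano and not the group on the sulfonyl sulfur, so it gives no guidance on this change, and nothing beyond the scatter is foreseen with confidence. For compound 3 the expected step is a number 4.2 percentage points lower from compound 2 to compound 3 (within the scatter), an estimated 78% with a range from 55% to 95%.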

Compound 3, largest response reached (Emax), in percent of the reference or control that the assay uses: 78.3%
The estimate for compound 3 lay 0.3 percentage points below the measured number, within the range that was stated.
By their numbers in this assay, from the lowest: compounds 3, 2 and 1 (each within the scatter of the next).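

In this assay, dimethylamino in place of (4-nitrophenyl)amino on the sulfonyl sulfur gives a number 3.9 percentage points lower from compound 2 to compound 3 (within the scatter), and dimethylamino in place of (4-cyanophenyl)amino gives a number 5.7 percentage points lower from compound 1 to compound 3 (within the scatter). The group on this sulfur can therefore lose its aromatic ring and its hydrogen-bond donor without compound 3 being set apart from compound 2 or compound 1 beyond the scatter. Nothing at hand explains this result.

Open, from the compounds shown here alone, is whether a carboxylic acid on the aryl ring, or piperidin-1-yl or a longer dialkylamino chain on the sulfonyl sulfur, would shift the maximal response beyond the scatter.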